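A few compounds are considered here, and "the series" means these few. Any claim that something is new, unique, unknown or untested is made for them only; others in the source may bear on it.

Compound 1 `C#CCN(CC=C)C(=O)[C@@]1(c2ccsc2)C[C@H]1CN`: > 10000 nM
Compound 2 `CCN(CC)C(=O)[C@@]1(c2ccc(Cl)s2)C[C@H]1CN`: > 10000 nM

Of the compounds shown here, two that share a core have been measured in an assay on HEK293 cells for inhibition of sodium-dependent dopamine transporter (Homo sapiens); a higher number here means a weaker inhibitor, a lower number a stronger inhibitor. In this assay compound 1 gives > 10000 nM, which is a limit of the assay and not a number. Compound 2 likewise gives > 10000 nM, again a limit rather than a number. Among the compounds with values here, compound 1 therefore stands nowhere in particular among the values shown: both sit at the limit of > 10000 nM in this assay, at which 2 of the 2 values shown sit, and no step between measured compounds can be read from them.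

Compound 3 `C=CCN(CCOC)C(=O)[C@@]1(c2ccsc2)C[C@H]1CN` has not yet been measured in this assay. It differs from compound 1 by methoxymethyl in place of ethynyl on a saturated chain carbon bound to an amide-type nitrogen. Since compound 1 is known only as a limit, no shift beyond the scatter is expected, and the step from compound 1 to compound 3 is estimated as a step that the limit leaves unreadable from compound 1 to compound 3. Compound 3 is expected to give 15000 nM in this assay, within a range from 5000 nM to 50000 nM, most likely again reported as a limit.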

Compound 3, half-maximal inhibitory concentration: > 10000 nM
Compound 3: only a limit was reported; the forecaster's own chance of this, stated with the estimate: 80%; the middle value is on the limit's open side.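

In this assay compound 3 gives > 10000 nM as a limit of the assay and not a number. No step can be read between compound 1 and compound 3, because their values offer no numbers to compare: the limit of > 10000 nM in this assay, at which 3 of the 3 values shown sit. The compounds shown leave open how strongly any of them inhibits, and whether propargyl and 2-methoxyethyl differ at all in this assay.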